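A few compounds are considered here, and "the series" means these few. Any claim that something is new, unique, unknown or untested is made for them only; others in the source may bear on it.

Compound 1, `CN1CCN(CC(=O)Nc2ccc(-c3nc(-c4ccccc4)c(-c4ccccc4)n3C)cc2)CC1`: 76.5 ug/mL
Compound 2, `CN(C)/C=C/N1CCN(CC(=O)Nc2ccc(-c3nc(-c4ccccc4)c(-c4ccccc4)n3C)cc2)CC1`: 80 ug/mL
Compound 3, `Cn1c(-c2ccc(NC(=O)CN3CCN(Cc4ccccc4)CC3)cc2)nc(-c2ccccc2)c1-c1ccccc1`: 80 ug/mL

In a functional assay on MCF7 cells (Homo sapiens) for cytotoxicity, read by MTT assay, with a stated time of 24 h (a higher number here means a weaker inhibitor, a lower number a stronger inhibitor), compound 3 gives 80 ug/mL, level with compound 2 at the digits printed, the two together the highest of the three numbers, though every gap here is within the scatter: a 1.0-fold higher number from compound 1 to compound 3 (0.02 log units; within the scatter), no change at the digits printed from compound 2 to compound 3 (within the scatter), a 1.0-fold higher number from compound 1 to compound 2 (0.02 log units; within the scatter). Compound 4, `COc1ccc(CN2CCN(CC(=O)Nc3ccc(-c4nc(-c5ccccc5)c(-c5ccccc5)n4C)cc3)CC2)cc1`, differs from compound 3 by methoxy in place of hydrogen on an aromatic carbon. For the measured compounds named here, no measured step touches this ring; the three steps that exist all swap the group on the ring nitrogen and all sit within the scatter, so nothing in the data points to a shift beyond it. Compound 4 is therefore expected to give 80 ug/mL, between 40 ug/mL and 160 ug/mL. The expected step is no change at the digits printed from compound 3 to compound 4 (within the scatter), none beyond the scatter.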

Compound 4, half-maximal inhibitory concentration: 80 ug/mL
Beside the measured number, compound 4's estimate shows no gap at the digits printed; the range from low to high includes it.
By their numbers in this assay, from the lowest: compounds 1, 2, 3 and 4 (each within the scatter of the next).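

For the compounds shown here, on the aromatic ring of the benzyl group, a site the earlier steps did not touch, methoxy in place of hydrogen in this assay gives no change at the digits printed from compound 3 to compound 4 (within the scatter). The swaps on the ring nitrogen also stay within the scatter, with no change at the digits printed from compound 2 to compound 4 (within the scatter) and a 1.0-fold higher number from compound 1 to compound 4 (0.02 log units; within the scatter), so 4-methoxybenzyl reads level with the groups already there. No evidence at hand bears on this result. Still open, as far as these compounds go, is whether a carboxylic acid or an amine on this aromatic ring would stay within the scatter, and whether a longer chain in place of benzyl on the ring nitrogen would.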